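The source may report more compounds than this note shows. Statements on the series, on what has been measured and on what is new or still open speak of the compounds shown alone.

Measured in a functional assay on A2780 cells (Homo sapiens) for antiproliferative activity, read by MTT assay, with a stated time of 48 h; on this read-out higher numbers stand for weaker inhibition and lower numbers for stronger inhibition:
Compound 1 `COc1ccc(-n2c(=O)[nH]c3cnc(-c4cc(OC)c(OC)c(OC)c4)cc32)cc1O`: > 20000 nM (a limit)
Compound 2 `COc1ccc(-c2cc3c(cn2)n(C)c(=O)n3-c2cc(OC)c(OC)c(OC)c2)cc1O`: 1720 nM

Compound 1 gives > 20000 nM, which is a limit of the assay and not a number. Among the compounds with values here, compound 2, at 1720 nM, holds the only actual number so far, so it is the sole numerical reference point for the series.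

The next compound is compound 3 `COc1ccc(-c2cc3c(cn2)n(CC(N)=O)c(=O)n3-c2cc(OC)c(OC)c(OC)c2)cc1O`. Its change from compound 2 is carbamoyl in place of hydrogen on a saturated chain carbon bound to an aromatic nitrogen. The same difference can be read as methyl to carbamoylmethyl.

Within the data shown here, no measured step covers this kind of change, so the expectation rests on compound 2 at 1720 nM and on the structural change alone. In this assay a modest step towards weaker inhibition is expected, about the size of the usual scatter or slightly beyond it, and with low confidence. The expected change is a 1.7-fold higher number from compound 2 to compound 3 (0.24 log units; within the scatter). For compound 3 the estimated value is 3000 nM, with an expected range from 800 nM to 12000 nM.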

Compound 3, half-maximal inhibitory concentration: 9880 nM
Compound 3: the middle estimate sits 3.3-fold (0.52 log units) below what was measured; measured number inside the range.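

In this assay, carbamoyl in place of hydrogen on the saturated chain carbon bound to an aromatic nitrogen gives a 5.7-fold higher number from compound 2 to compound 3 (0.76 log units; beyond the scatter), so this position is not indifferent to what it carries. Within the data shown here, this is the first step that changes one place only, and the change from methyl to carbamoylmethyl runs towards weaker inhibition, by more than the usual scatter. Compound 3 still gives a real number rather than a limit, so this change weakens the read-out without taking it out of the measurable range: the limit of > 20000 nM in this assay, at which 1 of the 3 values shown sits.

As far as these compounds go, whether an ethyl chain, a longer alkyl chain, an aminoethyl chain or a carboxylic acid on the same carbon would read close to compound 2 or close to compound 3 stays open. A single step therefore cannot separate the contribution of the carbamoyl group itself from that of any chain longer than methyl, and its size rests on one pair of compounds in one assay.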